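Benzyl arm swap: from compound 2 to compound 4

The source may report more compounds than this note shows. Statements on the series, on what has been measured and on what is new or still open speak of the compounds shown alone.

Three compounds sharing one core have been run in a functional assay on SK-MEL-2 cells (Homo sapiens) for inhibition, read by sulforhodamine B assay, with a stated time of 48 h; on this read-out higher numbers stand for weaker inhibition of growth and lower numbers for stronger inhibition of growth. Compound 1 `CCOC(=O)[C@H](CCC(=O)O)NC(=O)c1ccc(CNc2nc3cc(N)cc(N)c3nc2-c2ccccc2)cc1` gives 77600 nM in this assay, and compound 3 `CCOC(=O)[C@H](CCC(=O)O)NC(=O)c1ccc(Sc2nc3cc(N)cc(N)c3nc2-c2ccccc2)cc1` gives 63100 nM. Compound 2 `Nc1cc(N)c2nc(-c3ccccc3)c(NCc3ccc(Cl)c(Cl)c3)nc2c1` gives 4270 nM in this assay, the lowest of the three numbers; its gaps to compound 1 and to compound 3 both lie beyond the scatter, so compound 2 is the strongest growth inhibitor among the measured set. Compounds 1 and 3 carry a glutamate-bearing benzamide on the core, compound 2 a plain substituted benzyl on the ring nitrogen.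

Compound 4 `COc1ccc(CNc2nc3cc(N)cc(N)c3nc2-c2ccccc2)cc1` is not yet measured. It differs from compound 2 in one place: 4-methoxyphenyl in place of 3,4-dichlorophenyl on a saturated chain carbon bound to a nitrogen on an aromatic ring. Among the measured compounds shown here, no measured pair isolates a change of this kind, so the size of the step rests on judgement alone. The expectation is a step toward weaker inhibition of growth, moderate rather than large, from compound 2 to compound 4 of a 2.8-fold higher number from compound 2 to compound 4 (0.45 log units; beyond the scatter) in this assay. On that basis compound 4 is estimated to give 12000 nM in this assay, within a range from 3500 nM to 40000 nM.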

Compound 4, concentration for total growth inhibition: 28800 nM
The estimate for compound 4 lay 2.4-fold (0.38 log units) below the measured number; the range from low to high includes it.
By their numbers in this assay, from the lowest: compound 2; then compound 4; then compounds 3 and 1 (each within the scatter of the next).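

In this assay, the arm on a saturated chain carbon bound to a nitrogen on an aromatic ring now has its first single-change reading: 4-methoxyphenyl in place of 3,4-dichlorophenyl gives a 6.7-fold higher number from compound 2 to compound 4 (0.83 log units; beyond the scatter). Among the compounds shown here, the earlier compounds held no pair differing in one place, so this is the first direct sign that the aryl group at this position alone can move the number on the shared core, with 3,4-dichlorobenzyl the lower-number arm of the two. Nothing measured here speaks to what lies behind the step.

The step removes two chlorines and brings in a methoxy group in one move, so the compounds shown do not separate the contribution of the departing group from that of the entering one. An unsubstituted benzyl arm on the same core would divide the step into those two parts, and a phenethyl arm would show whether the length of the chain at this position also moves the number.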